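This account rests on a few compounds, and the source may have more. Where it says the series, first, only, none or still open, it means among the compounds named here.

Compound 1 `O=C(Nc1cccc(-n2cc(-c3ccncc3)c(-c3ccc(Cl)c(O)c3)n2)c1)Nc1ccc(Cl)c(Cl)c1`: 730 nM
Compound 2 `COc1cc(-c2nn(-c3cccc(NC(=O)c4ccc(Cl)c(C(F)(F)F)c4)c3)cc2-c2ccncc2)ccc1Cl`: 3690 nM
Compound 3 `O=C(Nc1cccc(-n2cc(-c3ccncc3)c(-c3ccc(Cl)c(O)c3)n2)c1)Nc1cc(C(F)(F)F)cc(C(F)(F)F)c1`: 270 nM

All three compounds were tested in a functional assay on MDA-MB-468 cells (Homo sapiens) for inhibition, read by sulforhodamine B assay, with a stated time of 48 h; a higher number here means a weaker inhibitor, a lower number a stronger inhibitor. Compound 3 gives the lowest number of the three, 270 nM. Its nearest neighbour is compound 1 at 730 nM, a gap that lies beyond the usual scatter, and the furthest is compound 2 at 3690 nM, also beyond the scatter. Compound 3 is therefore the strongest inhibitor among the measured compounds.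

Compound 4 `O=C(Nc1cccc(-n2cc(-c3ccncc3)c(-c3ccc(Cl)c(O)c3)n2)c1)Nc1cccc(C(F)(F)F)c1` has not yet been measured. It differs from compound 3 in a single place: hydrogen in place of trifluoromethyl on an aromatic carbon. Within the data shown here, no measured pair shows this same change, so the size of the step has to be judged from what the three measured compounds show. Among the measured compounds shown here, compound 3 carries two trifluoromethyl groups and gives the lowest number, while compound 1, with different groups on that ring, gives the higher value 730 nM; the data give no measured step for the removal of one trifluoromethyl group. The step in this assay is expected to be a modest rise in the number, a 2.2-fold higher number from compound 3 to compound 4 (0.35 log units; beyond the scatter), that is, somewhat weaker inhibition, probably just beyond the scatter. Compound 4 is accordingly estimated at 600 nM, with a range from 250 nM to 1500 nM.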

Compound 4, half-maximal inhibitory concentration: 980 nM
Compound 4: the middle estimate sits 1.6-fold (0.21 log units) below what was measured; measured number inside the range.
By their numbers in this assay, from the lowest: compound 3; then compounds 1 and 4 (each within the scatter of the next); then compound 2.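

In this assay, hydrogen stands where one trifluoromethyl group stood. The step is a 3.6-fold higher number from compound 3 to compound 4 (0.56 log units; beyond the scatter), so this aromatic carbon is a place where the change shows up in the number, and the second trifluoromethyl group is not interchangeable with hydrogen here. Replacing 3,4-dichlorophenyl with 3-(trifluoromethyl)phenyl on the amide-type nitrogen gives a 1.3-fold higher number from compound 1 to compound 4 (0.13 log units; within the scatter), which is within the usual scatter, so these two end groups cannot be told apart in this measurement. Nothing measured here explains the size of either step.

Going by these compounds, it remains open how a nitrile, a methoxy group or an amine would behave on this same carbon. On these data alone, it is also open whether the hydrogen-for-trifluoromethyl step would be similar on a different core.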